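Swapping an aromatic ring for a saturated one at the hydroxyl carbon

This account rests on a few compounds, and the source may have more. Where it says the series, first, only, none or still open, it means among the compounds named here.

Compound 1 `O=C(NCc1cc(Cl)ccc1-n1cnnn1)[C@@H]1C[C@@H]2C[C@@H]2N1C(=O)[C@H](O)c1ccccc1F`: < 12 mL.min-1.g-1
Compound 2 `CCCC[C@@H](O)C(=O)N1[C@@H]2C[C@@H]2C[C@H]1C(=O)NCc1cc(Cl)ccc1-n1cnnn1`: 89 mL.min-1.g-1

In an ADME assay on liver for metabolic stability, with Liver microsome (Homo sapiens) as the target, read by LC-MS, using microsomes (a lower number here means slower removal, a higher number faster removal of the compound), compound 1 gives < 12 mL.min-1.g-1, which is a limit of the assay rather than a number. In this assay compound 2 gives 89 mL.min-1.g-1. Compound 1 thus sits at the limit of < 12 mL.min-1.g-1 in this assay, at which 1 of the 2 values shown sits, so its true value is known only as lying at or under that limit.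

Compound 3 `O=C(NCc1cc(Cl)ccc1-n1cnnn1)[C@@H]1C[C@@H]2C[C@@H]2N1C(=O)[C@H](O)C1CCCCC1` is not yet measured. It differs from compound 1 by cyclohexyl in place of 2-fluorophenyl on a saturated chain carbon bound to a carbonyl carbon and an oxygen on a saturated carbon. Going by the values given here, no measured pair shows this change. Where compound 1 carries the 2-fluorophenyl, compound 2 carries a saturated chain and gives 89 mL.min-1.g-1, so a step upward, beyond the usual scatter, is expected here as an at least 4.1-fold higher number from compound 1 to compound 3 (0.61 log units; beyond the scatter). Compound 3 is expected to give 50 mL.min-1.g-1 in this assay, likely between 15 mL.min-1.g-1 and 150 mL.min-1.g-1.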

Compound 3, intrinsic clearance in microsomes: 150 mL.min-1.g-1
Beside the measured number, compound 3's estimate is 3.0-fold (0.48 log units) below it; low and high end bracket the measured number.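

This pair isolates the change at the hydroxyl carbon: in this assay, cyclohexyl in place of 2-fluorophenyl gives an at least 12-fold higher number from compound 1 to compound 3 (1.09 log units; beyond the scatter) on an otherwise identical compound. Removal in this test is therefore highly sensitive to which ring sits at this position, a point compound 2, with its saturated chain, could not show. The size of the step is only a minimum, because compound 1 stands at a limit of the assay: the limit of < 12 mL.min-1.g-1 in this assay, at which 1 of the 3 values shown sits.

The compounds shown do not separate the loss of aromaticity from the loss of fluorine. A plain phenyl, or a cyclohexyl bearing fluorine, would address that question.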